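The source may hold more compounds than are shown below. What is called first, only, known or untested is meant among the compounds shown, and "the series" means these compounds.

Of the compounds shown here, two that share one core have been tested in a functional assay on SGC-7901 cells (Homo sapiens) for cytotoxicity, read by MTT assay, with a stated time of 72 h; a lower number here means a stronger inhibitor, a higher number a weaker inhibitor. Compound 1, `CN(C)CCCNc1nc(N/N=C/c2ccc(F)cc2Cl)nc2ccccc12`, in this assay gives 1660 nM. Compound 2, `CN(C)CCNc1nc(N/N=C/c2nccn2Cc2ccccc2)nc2ccccc12`, in this assay gives 4300 nM, the higher of the two numbers, and the gap between them lies beyond the usual scatter of repeated measurements, so compound 2 is the weaker inhibitor of the pair. The unmeasured compound 3, `Cc1ccc(Cn2ccnc2/C=N/Nc2nc(NCCN(C)C)c3ccccc3n2)cc1`, comes from compound 2 by a single change: methyl in place of hydrogen on an aromatic carbon, para to a large group, which turns the benzyl group into a 4-methylbenzyl group. Going by the values given here, no pair of measured compounds isolates this change, so its size cannot be read from the numbers at hand. With nothing to point in either direction, the step expected for this change is one that stays within the scatter, a 1.1-fold lower number from compound 2 to compound 3 (0.03 log units; within the scatter). Compound 3 is therefore estimated to give 4000 nM in this assay, within a range from 1500 nM to 10000 nM.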

Compound 3, half-maximal inhibitory concentration: 2750 nM
The estimate for compound 3 lay 1.5-fold (0.16 log units) above the measured number; the measured number falls inside the stated range.
By their numbers in this assay, from the lowest: compounds 1, 3 and 2 (each within the scatter of the next, the first and the last beyond it).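

In this assay, going by these compounds alone, the change from benzyl to 4-methylbenzyl is the first single change that can be read on its own, and it gives a 1.6-fold lower number from compound 2 to compound 3 (0.19 log units; within the scatter). The aromatic carbon para to a large group can therefore carry a methyl without the number moving past what repeated measurements would show, so compound 2 and compound 3 cannot be told apart in this test, and this one added carbon is accepted at this place on the ring. No separate measurement bears on this result, so it stands as an observation without an explanation.

As far as these compounds go, one methyl is only a small probe of this position, so it remains open whether a bigger or different group on the same carbon, such as a methoxy group, a chlorine atom, a trifluoromethyl group, an amine or a carboxylic acid, would keep the number where it is or shift it beyond the scatter. Also open, from the compounds shown here alone, is whether a methyl on the other carbons of this ring would behave in the same way.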